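Bringing a ring back onto the carbonyl of compound 3

The source may hold more compounds than are shown below. What is called first, only, known or untested is meant among the compounds shown, and "the series" means these compounds.

Three compounds share one core and differ only in the group attached to a carbonyl carbon whose other neighbour is an amide-type nitrogen in a ring. Compound 1 `Cc1nc(S(C)(=O)=O)ccc1Oc1ncnc(OC2CCN(C(=O)OC3(C(F)(F)F)CCC3)CC2)c1F` gives 14.3 nM in a functional assay on isolated protein for inhibition of Glucose-dependent insulinotropic receptor (Homo sapiens), read by HTRF and cAMP accumulation; a higher number here means that more compound is needed for the effect, a lower number that less compound is needed. Compound 2 `Cc1nc(S(C)(=O)=O)ccc1Oc1ncnc(OC2CCN(C(=O)SC3CC3)CC2)c1F` gives 24.9 nM. Compound 3 `Cc1nc(S(C)(=O)=O)ccc1Oc1ncnc(OC2CCN(C(=O)C(F)(F)F)CC2)c1F` gives 151 nM, the highest of the three numbers; the step of an 11-fold higher number from compound 1 to compound 3 (1.02 log units; beyond the scatter) and the step of a 6.1-fold higher number from compound 2 to compound 3 (0.78 log units; beyond the scatter) both lie beyond the scatter, so compound 3 needs clearly more compound than either.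

Compound 4 `Cc1nc(S(C)(=O)=O)ccc1Oc1ncnc(OC2CCN(C(=O)C3(F)CCC3)CC2)c1F` is not yet measured. The change (a group of 5 heavy atoms (4 carbon, 1 fluorine; one four-membered non-aromatic ring of carbon only) in place of a group of 4 heavy atoms (1 carbon, 3 fluorine; no ring), on a carbonyl carbon). Both measured steps that end at compound 3 describe the loss of a ring-bearing group in favour of trifluoromethyl, and both raised the number. Reversing that direction, a ring-bearing group returning in place of trifluoromethyl, is expected to lower the number, by a step of a size between the two measured ones. Compound 4 is therefore estimated at 30 nM in this assay, within 10 nM to 90 nM, an expected step of a 5.0-fold lower number from compound 3 to compound 4 (0.70 log units; beyond the scatter).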

Compound 4, half-maximal effective concentration: 24.7 nM
Compound 4: the middle estimate sits 1.2-fold (0.08 log units) above what was measured; measured number inside the range.
By their numbers in this assay, from the lowest: compounds 1, 4 and 2 (each within the scatter of the next); then compound 3.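

In this assay, the step of a 6.1-fold lower number from compound 3 to compound 4 (0.79 log units; beyond the scatter) shows that a ring-bearing group can replace trifluoromethyl on this carbonyl carbon and lower the number without any oxygen or sulfur among its atoms. For the compounds shown here, the steps of a 1.0-fold lower number from compound 2 to compound 4 (0.00 log units; within the scatter) and a 1.7-fold higher number from compound 1 to compound 4 (0.24 log units; within the scatter) both lie within the scatter, so the three ring-bearing groups cannot be told apart, and only trifluoromethyl, the one group here without a ring, stands clearly apart. The oxygen of compound 1 and the sulfur of compound 2 are therefore not required for a number in this range.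

The compounds shown leave open whether the single fluorine of compound 4 contributes, since the same four-membered ring without fluorine is absent, and whether an open chain such as tert-butyl would match the ring. No supporting measurement explains the difference between the ring-bearing groups and trifluoromethyl.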